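Acid dissociation notes on two matched benzylamine pairs

The source may report more compounds than this note shows. Statements on the series, on what has been measured and on what is new or still open speak of the compounds shown alone.

Measured in a physicochemical assay for acid dissociation:
compound 1 `CN(Cc1ccc(N(C)C)cc1)Cc1cccc(CNc2ccnc3cc(Cl)ccc23)c1`: 7.36
compound 2 `CN(Cc1ccc(N(C)C)cc1)Cc1ccccc1CNc1ccnc2cc(Cl)ccc12`: 7.4
compound 3 `COc1ccc(CN(C)Cc2cccc(CNc3ccnc4cc(Cl)ccc34)c2)cc1`: 7.38

Compound 1 and compound 3 differ by methoxy in place of dimethylamino on an aromatic carbon; the step is a number 0.02 log units higher from compound 1 to compound 3 (within the scatter). Compound 2 and compound 1 have the same atoms joined differently; how their cores differ is not broken down here, and in this assay compound 2 gives 7.4 against compound 1 at 7.36, within the scatter of each other. Compound 4 `COc1ccc(CN(C)Cc2ccccc2CNc2ccnc3cc(Cl)ccc23)cc1` is not yet measured; it differs from compound 2 by methoxy in place of dimethylamino on an aromatic carbon, the same change seen from compound 1 to compound 3 at the same place. The step from compound 2 to compound 4 is expected to be a number 0.02 log units higher from compound 2 to compound 4 (within the scatter), beside a number 0.02 log units higher from compound 1 to compound 3 (within the scatter), because the earlier step of a number 0.02 log units higher from compound 1 to compound 3 (within the scatter) lies within the scatter. In this assay compound 4 is estimated at 7.42, expected between 7.2 and 7.65.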

Compound 4, acid dissociation constant: 7.47
Compound 4: the middle estimate sits 0.05 log units below what was measured; the measured number falls inside the stated range.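

In this assay, methoxy in place of dimethylamino gives a number 0.07 log units higher from compound 2 to compound 4 (within the scatter), and on the core of compound 1 the same change gives a number 0.02 log units higher from compound 1 to compound 3 (within the scatter). Across these two cores the change therefore carries over with no readable step, and the read-out does not separate the two groups. Two pairs show only this, and they set no rule for other cores or for a change that gives a step beyond the scatter; nothing available bears on the reason for these numbers.

Still open, going by these compounds, is whether a carboxylic acid or a primary amine in place of methoxy, at the same aromatic carbon, would give a step beyond the scatter on either core. A third core carrying the 4-methoxybenzyl group would test whether the pattern extends further.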